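Methyl on One Oxygen or the Other

The source may hold more compounds than are shown below. What is called first, only, known or untested is meant among the compounds shown, and "the series" means these compounds.

Compound 1 `COc1ccc(C(=O)/C=C/c2ccc(F)cc2)c(O)c1`: in an assay on isolated protein for inhibition of DNA topoisomerase 1 (Homo sapiens), tested at 20 uM (a higher number here means a stronger effect of the compound at the concentration tested, a lower number a weaker effect), compound 1 gives 60%.
Compound 2 `O=C(/C=C/c1ccc(F)cc1)c1ccc(O)cc1O`: compound 2 gives 56.7%.

Compound 2 has the lower of the two numbers, yet the measured step of a number 3.3 percentage points lower from compound 1 to compound 2 (within the scatter) lies within the scatter, so the two compounds cannot be ranked. Compound 3 `COc1cc(O)ccc1C(=O)/C=C/c1ccc(F)cc1` differs from compound 2 by methyl in place of hydrogen on an oxygen on an aromatic ring. That single measured step is the reverse kind of change, hydroxy to methoxy read the other way, and it moved nothing beyond the scatter. A step of similar size, a number 1.3 percentage points higher from compound 2 to compound 3 (within the scatter), is therefore expected for compound 3. Compound 3 is estimated at 58%, with a range from 46% to 70%.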

Compound 3, a percentage reported as inhibition, at one concentration (the size of the read-out at that concentration, not a potency): 61.6%
Compound 3: the middle estimate sits 3.6 percentage points below what was measured; low and high end bracket the measured number.
By their numbers in this assay, from the lowest: compounds 2, 1 and 3 (each within the scatter of the next).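

In this assay, methyl in place of hydrogen on an oxygen on an aromatic ring gives a number 4.9 percentage points higher from compound 2 to compound 3 (within the scatter). So the change at this oxygen, like the change at the other oxygen that separates compound 1 from compound 2, produces no difference that can be read. Nothing measured here offers an explanation for this result.

As far as these compounds go, whether methyl on both oxygens would leave the number within the scatter remains open. So does the outcome with a longer chain, such as ethyl, on either oxygen, or with an amine in place of either hydroxy.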